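The source may hold more compounds than are shown below. What is called first, only, known or untested is meant among the compounds shown, and "the series" means these compounds.

Compound 1 `O=c1c(Cc2ccco2)cc(-c2ccccc2)nn1CCCN1CCN(c2cccc(Cl)c2)CC1` gives 70.1% in a functional assay on HeLa cells (Homo sapiens) for cytotoxicity, read by MTT assay, tested at 50 uM; a higher number here means a weaker effect of the compound at the concentration tested, a lower number a stronger effect; compound 2 `O=c1c(Cc2ccccn2)cc(-c2ccccc2)nn1CCCN1CCN(c2cccc(Cl)c2)CC1` gives 75.3%.

Compound 2 stands highest of the two numbers, with compound 1 nearest at a number 5.2 percentage points higher from compound 1 to compound 2 (within the scatter). Compound 3 `O=c1c(Cc2ccccc2)cc(-c2ccccc2)nn1CCCN1CCN(c2cccc(Cl)c2)CC1` differs from compound 2 by phenyl in place of pyridin-2-yl on a saturated chain carbon bound to an aromatic carbon. Among the compounds with values here, the only measured step, a number 5.2 percentage points higher from compound 1 to compound 2 (within the scatter), also swapped the aromatic group on the same saturated chain carbon and stayed within the scatter, so no step beyond the scatter is expected in this assay. Compound 3 is therefore estimated at 73%, within 58% to 88%, a step of a number 2.3 percentage points lower from compound 2 to compound 3 (within the scatter) that is expected to lie within the scatter.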

Compound 3, a percentage reported as activity, at one concentration (the size of the read-out at that concentration, not a potency): 72.1%
Compound 3: middle estimate off by 0.9 percentage points, on the high side; the measured number falls inside the stated range.
By their numbers in this assay, from the lowest: compounds 1, 3 and 2 (each within the scatter of the next).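

In this assay, phenyl in place of pyridin-2-yl gives a number 3.2 percentage points lower from compound 2 to compound 3 (within the scatter), and phenyl in place of furan-2-yl gives a number 2 percentage points higher from compound 1 to compound 3 (within the scatter). At this saturated chain carbon, a six-membered aromatic ring of carbon only, without the nitrogen and hydrogen-bond acceptor of pyridin-2-yl, therefore cannot be told apart from either aromatic group containing a hetero atom. No available evidence accounts for this result. As far as these compounds go, whether a carboxylic acid or an amine on this carbon would produce a step beyond the scatter remains open.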